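The compounds below may be only part of what the source reports. "The series", "measured", "known", "first", "only" and "open" are said of these compounds alone.

Compound 1, `CCCCCCCCCc1ccc(NC(=O)Nc2c(C(C)C)cccc2C(C)C)cc1`, is the stronger of the two measured compounds: in an assay on isolated protein for inhibition of acyl-CoA:cholesterol acyltransferase (Oryctolagus cuniculus) (a lower number here means a stronger inhibitor, a higher number a weaker inhibitor), compound 1 gives 9 nM, the lowest of the two numbers. Compound 2, `CCCCCCCc1ccc(NC(=O)Nc2c(C(C)C)cccc2C(C)C)cc1`, gives 19 nM in this assay, and the step of a 2.1-fold higher number from compound 1 to compound 2 (0.32 log units; beyond the scatter) shows that trimming the chain costs some potency. Compound 3, `CC(C)c1cccc(C(C)C)c1NC(=O)Nc1ccc(C(C)(C)C)cc1`, goes much further in the same direction: tert-butyl in place of nonyl on an aromatic carbon. For the measured compounds named here, the only guide is that shortening step from compound 1 to compound 2, which was modest; replacing the whole nonyl chain with a far shorter group is expected to weaken inhibition more clearly, as a 13-fold higher number from compound 1 to compound 3 (1.12 log units; beyond the scatter). Compound 3 is therefore estimated at 120 nM, within 30 nM to 500 nM.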

Compound 3, half-maximal inhibitory concentration: 168 nM
For compound 3 the middle estimate is 1.4-fold (0.15 log units) below the measured one; measured number inside the range.
By their numbers in this assay, from the lowest: compound 1; then compound 2; then compound 3.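

In this assay, the aromatic carbon para to a large group turns out to be far more sensitive to the change of group than the trimming of the chain suggested: tert-butyl in place of nonyl gives a 19-fold higher number from compound 1 to compound 3 (1.27 log units; beyond the scatter) and tert-butyl in place of heptyl gives an 8.8-fold higher number from compound 2 to compound 3 (0.95 log units; beyond the scatter) at this same carbon. Tert-butyl differs from both chains in branching as well as in length, and these compounds cannot separate the two. Nothing available explains the loss.

Going by these compounds, whether an unbranched butyl chain would behave more like the long chains or more like tert-butyl remains open. So does the effect of a chain longer than nonyl, or of an amine, at this carbon.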